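This account rests on a few compounds, and the source may have more. Where it says the series, first, only, none or still open, it means among the compounds named here.

Compound 1, `CCCCCCCCCCCCn1nnc(C(NC(=O)c2ccccc2)c2ccccc2)n1`: 350 nM
Compound 2, `CCCCCCCCCCCCn1nnc(C(NC(=O)c2ccc(C)cc2)c2ccccc2)n1`: 510 nM
Compound 3, `CCCCCCCCCCCCn1nnc(C(NC(=O)c2ccccc2[N+](=O)[O-])c2ccccc2)n1`: 240 nM

In an assay on microsomes from liver for inhibition of sterol O-acyltransferase 1 (Rattus norvegicus) (a higher number here means a weaker inhibitor, a lower number a stronger inhibitor), compound 3 gives the lowest of the three numbers. Its separation from compound 2 is real, a 2.1-fold lower number from compound 2 to compound 3 (0.33 log units; beyond the scatter), while against compound 1 the gap is small, a 1.5-fold lower number from compound 1 to compound 3 (0.16 log units; within the scatter), so compound 3 and compound 1 cannot be ranked against each other on these numbers.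

Compound 4, `CCCCCCCCCCCCn1nnc(C(NC(=O)c2ccccc2C(F)(F)F)c2ccccc2)n1`, has not yet been measured in this assay. It differs from compound 3 in one place: trifluoromethyl in place of nitro on an aromatic carbon. Within the data shown here, two measured steps touch this position. The step from compound 1 to compound 3 introduced the nitro group at the same place, and it stayed within the scatter. The step of a 2.1-fold lower number from compound 2 to compound 3 (0.33 log units; beyond the scatter) was modest and combined two changes. Among the measured compounds shown here, no measured compound carries a trifluoromethyl group, so nothing shows how that group itself behaves here. Since the nitro group made little difference in a 1.5-fold lower number from compound 1 to compound 3 (0.16 log units; within the scatter), compound 4 is expected to land close to compound 3, with a step of a 1.3-fold higher number from compound 3 to compound 4 (0.10 log units; within the scatter) that is not expected to go beyond the scatter. Compound 4 is therefore estimated at 300 nM, with a range from 130 nM to 700 nM.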

Compound 4, half-maximal inhibitory concentration: 120 nM
Beside the measured number, compound 4's estimate is 2.5-fold (0.40 log units) above it, outside the stated range (below it).
By their numbers in this assay, from the lowest: compounds 4, 3, 1 and 2 (each within the scatter of the next, the first and the last beyond it).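

In this assay, among these compounds, trifluoromethyl is the first group at this position with a step from the unsubstituted compound beyond the scatter, a 2.9-fold lower number from compound 1 to compound 4 (0.46 log units; beyond the scatter), whereas the nitro step from that compound stayed within it. The swap of nitro for trifluoromethyl itself, a 2.0-fold lower number from compound 3 to compound 4 (0.30 log units; within the scatter), stays within the scatter, so the two groups cannot be ranked against each other, although a 4.3-fold lower number from compound 2 to compound 4 (0.63 log units; beyond the scatter) is wider than the step to compound 3 from the same starting point. No data shown here explain the effect of trifluoromethyl at this position.

The compounds shown leave open whether a chlorine, a methoxy group or an amine at the same place would also separate from compound 1 beyond the scatter. They also leave open how trifluoromethyl would behave at the place held by the methyl in compound 2.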